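The compounds below may be only part of what the source reports. "The series", "measured", "known", "first", "only" and "open" are said of these compounds alone.

Measured so far in an ADME assay on Vero cells (Chlorocebus sabaeus) for cytotoxicity, read by MTT assay, with a stated time of 96 h; a lower number here means that less compound is tolerated, a higher number that more compound is tolerated:
- compound 1 `CC(=O)c1ccc2c(c1)nc(-c1ccccc1)n2C1CCCCC1`: 80000 nM
- compound 2 `CC(=O)c1ccc2c(c1)nc(-c1ccc(Cl)cc1)n2C1CCCCC1`: > 100000 nM
- compound 3 `COc1ccc(-c2nc3cc(C(C)=O)ccc3n2C2CCCCC2)cc1`: 30000 nM

The entry for compound 2 is a limit of the assay, > 100000 nM, and not a number.

Compound 3 has the lowest number shown in this assay, 30000 nM. Compound 1 is its nearest neighbour, with a 2.7-fold lower number from compound 1 to compound 3 (0.43 log units; beyond the scatter). The next compound, compound 4 `COc1ccc(-c2nc3cc(/C(C)=N/NC(N)=S)ccc3n2C2CCCCC2)cc1`, keeps the core of compound 3 and replaces the acetyl on an aromatic carbon: a group of 7 heavy atoms (3 carbon, 3 nitrogen, 1 sulfur; no ring) in place of a group of 3 heavy atoms (2 carbon, 1 oxygen; no ring), on an aromatic carbon.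

Among the compounds with values here, no measured step touches this place. All three concern the substituent on the other aromatic ring: an at least 1.2-fold higher number from compound 1 to compound 2 (0.09 log units; that floor lies within the scatter), a 2.7-fold lower number from compound 1 to compound 3 (0.43 log units; beyond the scatter) and an at least 3.3-fold lower number from compound 2 to compound 3 (0.52 log units; beyond the scatter). They bear on the new change only indirectly, as a guide to the size of step this series can show. The modest 2.7-fold lower number from compound 1 to compound 3 (0.43 log units; beyond the scatter) is the closest guide, so a modest step towards a lower number is expected, with wide uncertainty. The expected step is a 2.5-fold lower number from compound 3 to compound 4 (0.40 log units; beyond the scatter). The estimate for compound 4 is 12000 nM, with an expected range of 3000 nM to 50000 nM.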

Compound 4, half-maximal cytotoxic concentration: 40000 nM
Beside the measured number, compound 4's estimate is 3.3-fold (0.52 log units) below it, and the stated range covers the measured number.
By their numbers in this assay, from the lowest: compounds 3, 4 and 1 (each within the scatter of the next, the first and the last beyond it). At a limit, above all of these: compound 2.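

In this assay, the only step shown at the acetyl position stays within the scatter (a 1.3-fold higher number from compound 3 to compound 4 (0.12 log units; within the scatter)), so a group of 7 heavy atoms with 2 hydrogen-bond donors in place of the acetyl leaves compound 3 and compound 4 indistinguishable in this assay. The earlier compounds shown here showed only changes on the other aromatic ring, where methoxy in place of hydrogen gives a step beyond the scatter (a 2.7-fold lower number from compound 1 to compound 3 (0.43 log units; beyond the scatter)), and they gave no reading at this aromatic carbon. No measurement shown here bears on why the replacement leaves the number within the scatter.

From the compounds shown here alone, whether an amine, a carboxylic acid or a longer chain at this aromatic carbon would also stay within the scatter remains open. Also open, going by these compounds, is whether the same replacement gives a similar result with hydrogen or chloro, rather than methoxy, on the other aromatic ring.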